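Benzyl for 4-Fluorophenyl on the Urea Nitrogen

The compounds below may be only part of what the source reports. "The series", "measured", "known", "first", "only" and "open" are said of these compounds alone.

Compound 1 `CCOC(=O)c1cnn(CC(C)O)c1NC(=O)Nc1ccc(F)cc1`: > 10 nM
Compound 2 `CCOC(=O)c1cnn(CC(C)O)c1NC(=O)Nc1cccc2ccccc12`: 9.8 nM
Compound 3 `CCOC(=O)c1cnn(C)c1NC(=O)NC(C)C`: 77 nM

Of the compounds shown here, three on a shared core have been tested in a functional assay on cells (Neutrophil, Homo sapiens) for inhibition, with a stated time of 10 min; a lower number here means a stronger inhibitor, a higher number a weaker inhibitor. Compound 1 is reported only as a limit of the assay, > 10 nM, not as a number. Compound 1 therefore stands at the limit of > 10 nM in this assay, at which 1 of the 3 values shown sits. Compound 2 gives 9.8 nM in this assay. Compound 3 gives 77 nM in this assay. For the measured compounds named here, no pair of measured compounds differs in a single place, so no measured step is available.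

Compound 4 `CCOC(=O)c1cnn(CC(C)O)c1NC(=O)NCc1ccccc1` differs from compound 1 by benzyl in place of 4-fluorophenyl on an amide-type nitrogen. The step expected from this change is a step that the limit leaves unreadable from compound 1 to compound 4, which, measured against a limit, cannot be set against the usual scatter. Compound 4 is expected to give about 50 nM, between 15 nM and 300 nM, an estimate resting on compound 3, which with an isopropyl group on the same position gives 77 nM in this assay.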

Compound 4, half-maximal inhibitory concentration: 15 nM
For compound 4 the middle estimate is 3.3-fold (0.52 log units) above the measured one; measured number inside the range.
By their numbers in this assay, from the lowest: compounds 2 and 4 (each within the scatter of the next); then compound 3.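

No step can be read from compound 1 to compound 4 in this assay, since compound 1 is reported only as a limit of the assay: the limit of > 10 nM in this assay, at which 1 of the 4 values shown sits.

The compounds shown leave open how large the change from 4-fluorophenyl to benzyl on an amide-type nitrogen is in this assay.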